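The source may hold more compounds than are shown below. What is called first, only, known or untested is meant among the compounds shown, and "the series" means these compounds.

Measured so far:
compound 1 `CC1=NN(C(=O)c2ccccc2)C(c2ccccc2O)C1`: 29400 nM
compound 2 `CC1=NN(C(=O)c2ccc(C)cc2)C(c2ccccc2O)C1`: 78900 nM
compound 3 `CC1=NN(C(=O)c2ccccc2C)C(c2ccccc2O)C1`: 95200 nM

In a functional assay on HepG2 cells (Homo sapiens) for cytotoxicity, read by MTT assay, with a stated time of 48 h (on this read-out lower numbers stand for stronger inhibition and higher numbers for weaker inhibition), compound 1 has the lowest number of the three. The next compound, compound 4 `CC1=NN(C(=O)c2ccccc2)C(c2cccc(C)c2O)C1`, has not yet been measured. It departs from compound 1 by one change, methyl in place of hydrogen on an aromatic carbon, ortho to a hydroxy group and meta to a large group.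

The nearest evidence is two other methyl-for-hydrogen steps, a 2.7-fold higher number from compound 1 to compound 2 (0.43 log units; beyond the scatter) and a 3.2-fold higher number from compound 1 to compound 3 (0.51 log units; beyond the scatter). Both are modest and both go upward. Their two methyl placements stay close to each other, at a 1.2-fold higher number from compound 2 to compound 3 (0.08 log units; within the scatter). All of these methyl groups, however, sit on the aromatic ring attached to the carbonyl carbon. Among the measured compounds shown here, no measured step puts a methyl on the ring carrying the hydroxy group, so these steps are only indirect guides. A rise in the same direction is expected, though a smaller one, and the estimated step is a 1.7-fold higher number from compound 1 to compound 4 (0.23 log units; within the scatter). For compound 4 the expected value is 50000 nM, with an estimated range of 20000 nM to 120000 nM.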

Compound 4, half-maximal inhibitory concentration: 177000 nM
For compound 4 the middle estimate is 3.5-fold (0.55 log units) below the measured one; the whole stated range lies below it.
By their numbers in this assay, from the lowest: compound 1; then compounds 2, 3 and 4 (each within the scatter of the next, the first and the last beyond it).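

With the methyl ortho to a hydroxy group and meta to a large group, this assay shows a 6.0-fold higher number from compound 1 to compound 4 (0.78 log units; beyond the scatter), the only step shown that places a methyl on the aromatic ring carrying the hydroxy group. The upward direction is therefore not confined to the ring attached to the carbonyl carbon: among compounds 2, 3 and 4, each methyl raises the number relative to compound 1, and none goes against this. No available evidence accounts for the rise at this position.

On these data alone, whether a chlorine atom, a methoxy group or an amine on this same carbon would move the number in the same direction remains open. The compounds shown also leave open what a methyl on the other carbons of this ring would do.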